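Fluoro in place of methoxy: expectation for compound 3

The source may hold more compounds than are shown below. What is called first, only, known or untested is meant among the compounds shown, and "the series" means these compounds.

Of the compounds shown here, two have been read in an assay on HEK293 cells for inhibition of Voltage-dependent T-type calcium channel subunit alpha-1G (Homo sapiens), read by fluorescence, tested at 10 uM; a higher number here means more inhibition at the concentration tested (going by the name of the read-out), a lower number less inhibition. Compound 1, `CCCc1nc(-c2ccccc2)c(CNCCN2CCN(c3ccccn3)CC2)o1`, gives 48.1% in this assay. Compound 2, `CCCc1nc(-c2ccccc2)c(CNCCN2CCN(c3cccc(OC)c3)CC2)o1`, gives 40.2%. Going by the values given here, the only step between measured compounds, a number 7.9 percentage points lower from compound 1 to compound 2 (within the scatter), is the exchange of pyridin-2-yl for 3-methoxyphenyl on the amine nitrogen in the ring, and it stays within the scatter. Among the compounds with values here, on the numbers so far, compound 2 holds the lowest of the two values, though its gap to compound 1 is within the scatter, so no order can be read from it.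

Compound 3, `CCCc1nc(-c2ccccc2)c(CNCCN2CCN(c3cccc(F)c3)CC2)o1`, carries the change (fluoro in place of methoxy on an aromatic carbon). Within the data shown here, no measured step touches this kind of exchange: the one step known concerns the whole aryl group on the nitrogen, not a substituent on the six-membered carbon-only ring. Among the measured compounds shown here, the only step on record was within the scatter, and the change here is smaller in heavy-atom count. The step to compound 3 is therefore expected to be small, a number 1.8 percentage points higher from compound 2 to compound 3 (within the scatter), with no clear direction. Compound 3 is estimated at 42% in this assay, within 25% to 60%.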

Compound 3, a percentage reported as inhibition, at one concentration (the size of the read-out at that concentration, not a potency): 62.3%
Compound 3: the middle estimate sits 20.3 percentage points below what was measured; the measured number lies above the stated range.
By their numbers in this assay, from the lowest: compounds 2 and 1 (each within the scatter of the next); then compound 3.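

In this assay, going by these compounds alone, fluoro in place of methoxy on an aromatic carbon of the six-membered aromatic ring of carbon only gives a number 22.1 percentage points higher from compound 2 to compound 3 (beyond the scatter), the first change to go beyond the scatter, so this position on the aryl group does respond to the exchange of one small substituent for another. The 3-fluorophenyl group also separates from the pyridin-2-yl group, with a number 14.2 percentage points higher from compound 1 to compound 3 (beyond the scatter), which places compound 3 highest of the three in this assay, whereas the earlier pair of compound 1 and compound 2 allowed no order. Nothing on hand gives a reason for either step.

The compounds shown leave open whether this step belongs to fluoro in particular or would also appear with chloro, trifluoromethyl, a nitrile or a plain hydrogen at the same place on the aryl group. They also leave open whether the same exchange of methoxy for fluoro holds on another core, and how these numbers at a single concentration translate into potency.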